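The source may hold more compounds than are shown below. What is called first, only, known or untested is meant among the compounds shown, and "the series" means these compounds.

Working notes on the series. Among the compounds with values here, in an assay on frontal cortex for displacement of a labelled ligand from corticotropin-releasing factor receptor 1 (Rattus norvegicus), with a stated time of 2 h (a lower number here means a stronger inhibitor, a higher number a weaker inhibitor), compound 2 `COc1nc(C)c(Nc2nc(Cl)cn([C@H](COC(=O)Nc3cc(Cl)cc(Cl)c3)C3CC3)c2=O)cc1C` gives 1.7 nM, the lowest of the two numbers so far; its nearest neighbour is compound 1 `COc1nc(C)c(Nc2nc(Cl)cn([C@H](COC(=O)c3ccccn3)C3CC3)c2=O)cc1C`, which in this assay gives 67 nM. Within the data shown here, the only step between measured compounds is a 39-fold lower number from compound 1 to compound 2 (1.60 log units; beyond the scatter), a change on the carbonyl carbon that exchanges both the linking atom and the aryl group at once, so it does not isolate the aryl group on the amide-type nitrogen. Compound 3 `COc1nc(C)c(Nc2nc(Cl)cn([C@H](COC(=O)Nc3cccnc3)C3CC3)c2=O)cc1C` differs from compound 2 by pyridin-3-yl in place of 3,5-dichlorophenyl on an amide-type nitrogen. Among the measured compounds shown here, no measured step bears directly on this exchange, and the one measured step moved a different part of the molecule. A moderately higher number is expected for compound 3, with a 7.1-fold higher number from compound 2 to compound 3 (0.85 log units; beyond the scatter) as the estimated step, without a firm anchor in the data. Compound 3 is estimated at 12 nM, range 3 nM to 50 nM.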

Compound 3, half-maximal inhibitory concentration: 10 nM
Estimate against measurement, compound 3: 1.2-fold (0.08 log units) above; measured number inside the range.
By their numbers in this assay, from the lowest: compound 2; then compound 3; then compound 1.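

In this assay, the aryl group on the amide-type nitrogen is now separated from the linking atom: pyridin-3-yl in place of 3,5-dichlorophenyl gives a 5.9-fold higher number from compound 2 to compound 3 (0.77 log units; beyond the scatter), so the aryl exchange alone moves the number. With a pyridine ring on both sides, (pyridin-3-yl)amino in place of pyridin-2-yl on a carbonyl carbon still gives a 6.7-fold lower number from compound 1 to compound 3 (0.83 log units; beyond the scatter), although this change alters both the linking atom and the point of attachment on the ring. Nothing available here accounts for either step.

Still open, as far as these compounds go, is whether the change at the amide-type nitrogen follows the ring nitrogen or the two chlorines, which phenyl or 3-chlorophenyl at this position would separate. The linking atom also remains unresolved, and pyridin-2-yl on the amide-type nitrogen would part it from the point of attachment.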